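The source may report more compounds than this note shows. Statements on the series, on what has been measured and on what is new or still open speak of the compounds shown alone.

Compound 1, `COc1ccc(/C=C/C(=O)c2ccccc2-c2ccc(OC)c(OC)c2)cc1`, gives 1100 nM in a functional assay on MCF7 cells (Homo sapiens) for antiproliferative activity, read by sulforhodamine B assay, with a stated time of 48 h; a higher number here means a weaker inhibitor, a lower number a stronger inhibitor.
Compound 2, `COc1ccc(/C=C/C(=O)c2ccccc2-c2ccc(OC)c(OC)c2)cc1OC`, gives 4900 nM.
Compound 3, `O=C(/C=C/c1ccccc1-c1ccc(F)cc1)c1cccc(O)c1`, gives 9300 nM.

Compound 4, `COc1ccc(C(=O)/C=C/c2ccccc2-c2ccc(F)cc2)cc1O`, is not yet measured. Compound 2 differs from compound 1 by methoxy in place of hydrogen on an aromatic carbon, and that change brought a 4.5-fold higher number from compound 1 to compound 2 (0.65 log units; beyond the scatter). Compound 4 differs from compound 3 by the same kind of change, (methoxy in place of hydrogen on an aromatic carbon); the surroundings differ, since here the new group sits ortho to a hydroxy group and para to a large group, whereas in compound 2 it sits ortho to a methoxy group and meta to a large group. The difference between the two cores is not broken down here. A step of similar direction is expected, a 2.4-fold higher number from compound 3 to compound 4 (0.37 log units; beyond the scatter), resting on the step from compound 1 to compound 2. Compound 4 is therefore estimated at 22000 nM, between 7000 nM and 60000 nM.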

Compound 4, half-maximal inhibitory concentration: 560 nM
Compound 4: middle estimate off by 39-fold (1.59 log units), on the high side; the measured number lies below the stated range.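

In this assay, methoxy in place of hydrogen on an aromatic carbon gave a 17-fold lower number from compound 3 to compound 4 (1.22 log units; beyond the scatter), the opposite direction to the earlier step. The size and even the direction of this change therefore cannot be carried from one core to another in this series, as the two steps disagree: the same change on two cores in this assay, a 4.5-fold higher number (0.65 log units; beyond the scatter) from compound 1 to compound 2 and a 17-fold lower number (1.22 log units; beyond the scatter) from compound 3 to compound 4, 74-fold (1.87 log units) apart, beyond the scatter of two such steps This does not show why they disagree, as the two cores are not broken down and the new group in compound 4 sits ortho to a hydroxy group and para to a large group.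

On these data alone, it remains open whether that hydroxy group matters, which an amine in its place could help test. Also open, as far as these compounds go, is how an ethoxy group, a longer chain, would compare with methoxy at the same place.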